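Methoxy for Fluoro on the Sulfonamide Aryl Ring

The source may report more compounds than this note shows. Statements on the series, on what has been measured and on what is new or still open speak of the compounds shown alone.

Going by the values given here, compound 1 `O=C1NCCN1c1ccc(S(=O)(=O)Nc2ccc(F)cc2)cc1` is one of two compounds measured in a functional assay on MCF7 cells (Homo sapiens) for antiproliferative activity, read by sulforhodamine B assay, with a stated time of 48 h (a higher number here means a weaker inhibitor, a lower number a stronger inhibitor), in which compound 1 gives 690 nM. Its companion, compound 2 `CCc1ccc(NS(=O)(=O)c2ccc(N3CCNC3=O)cc2)cc1`, gives 810 nM in this assay, and the step of a 1.2-fold higher number from compound 1 to compound 2 (0.07 log units; within the scatter) is too small to separate the two. Compound 3 `COc1ccc(NS(=O)(=O)c2ccc(N3CCNC3=O)cc2)cc1` has not yet been measured; it differs from compound 1 by methoxy in place of fluoro on an aromatic carbon. Among the compounds with values here, the only measured step that bears on this change is the one from compound 1 to compound 2, where ethyl in place of fluoro at the same aromatic carbon gave a 1.2-fold higher number from compound 1 to compound 2 (0.07 log units; within the scatter). Within the data shown here, with that as the sole precedent, a change of similar kind at that position is expected to move the number by a 1.1-fold higher number from compound 1 to compound 3 (0.04 log units; within the scatter), that is, no step beyond the scatter. Compound 3 is therefore expected to give about 750 nM in this assay, with a range from 350 nM to 1600 nM.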

Compound 3, half-maximal inhibitory concentration: > 1000 nM
Compound 3 gave a limit, no number; the forecaster's own chance of this, stated with the estimate: 3%; middle value at least 1.3-fold (0.12 log units) away from the limit.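

The place para to a large group gave numbers with fluoro and ethyl, but with the 4-methoxyphenyl group compound 3 gives only a limit of the assay, not a number: the limit of > 1000 nM in this assay, at which 1 of the 3 values shown sits.

In this assay, methoxy in place of fluoro gives an at least 1.4-fold higher number from compound 1 to compound 3 (0.16 log units; that floor lies within the scatter), and methoxy in place of ethyl gives an at least 1.2-fold higher number from compound 2 to compound 3 (0.09 log units; that floor lies within the scatter). Both are floors, so this change is not shown to cost activity beyond the scatter, yet such a loss is not excluded either, which the two earlier compounds alone could not have suggested.

On these data alone, the true size of the methoxy step stays open, as compound 3 has no number. Also open, as far as these compounds go, is how a hydroxyl, an amine or a longer chain such as propyl would read on this aromatic carbon.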